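Amide nitrogen substituent change in a kinase inhibitor series

The source may hold more compounds than are shown below. What is called first, only, known or untested is meant among the compounds shown, and "the series" means these compounds.

Measured so far:
- compound 1 `COc1cccc(CN(C(=O)c2c[nH]c3nc(-c4cn[nH]c4)ccc23)C2CC2)c1`: 30 nM
- compound 2 `COc1cccc(CN(C)C(=O)c2c[nH]c3cc(-c4cn[nH]c4)ccc23)c1`: 19 nM
- compound 3 `COc1cccc(CN(CCCN(C)C)C(=O)c2cn(C)c3cc(-c4cn[nH]c4)ccc23)c1`: 13 nM

These values come from an assay on isolated protein for inhibition of Rho-associated protein kinase 1 (Homo sapiens); on this read-out higher numbers stand for weaker inhibition and lower numbers for stronger inhibition. Compound 1 stands at the highest of the three numbers. The nearest is compound 2, whose number lies within the usual scatter of that of compound 1, so the two cannot be told apart. The furthest is compound 3, whose lower number lies beyond the scatter. Among the compounds with values here, no two of the measured compounds differ in a single place, so no single-change step is available from them, and the three compounds differ from one another at several places at once.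

Compound 4 `CCN(Cc1cccc(OC)c1)C(=O)c1c[nH]c2nc(-c3cn[nH]c3)ccc12` is the next compound for this assay. It differs from compound 1 by ethyl in place of cyclopropyl on an amide-type nitrogen; the rest of the structure is unchanged. A change of this kind on the amide nitrogen gives no reason, from the three measured compounds, to expect anything beyond the scatter. The step from compound 1 is expected to be no change at the digits printed from compound 1 to compound 4 (within the scatter), in no particular direction. Compound 4 is estimated at 30 nM, with a range from 12 nM to 75 nM.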

Compound 4, half-maximal inhibitory concentration: 76 nM
Compound 4: the middle estimate sits 2.5-fold (0.40 log units) below what was measured; measured number outside the range, above it.
By their numbers in this assay, from the lowest: compounds 3, 2 and 1 (each within the scatter of the next, the first and the last beyond it); then compound 4.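

Within the data shown here, on the core of compound 1, the group on this amide nitrogen is not neutral in this assay and ethyl in place of cyclopropyl gives a 2.5-fold higher number from compound 1 to compound 4 (0.40 log units; beyond the scatter) as the first single-change step. The step is modest but beyond the scatter, so even this small exchange of a three-membered ring for an open chain can be read at this position. No measured property bears on the step, so it stands without an explanation.

Isopropyl or cyclobutyl on the same nitrogen and the same core would help show whether the step follows the ring itself or the size of the group. Compounds 2 and 3 differ from compound 1 in several places, so they leave open whether the same step would hold on their cores.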